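The source may hold more compounds than are shown below. What is called first, only, known or untested is meant among the compounds shown, and "the series" means these compounds.

Measured so far in an assay on isolated protein for inhibition of vitamin D3 receptor (Homo sapiens), read by fluorescence polarization; on this read-out lower numbers stand for stronger inhibition and higher numbers for weaker inhibition:
compound 1 `CC(C)N(C(=O)CCNC(=O)c1ccc(S(C)(=O)=O)c([N+](=O)[O-])c1)C(C)C`: > 60000 nM
compound 2 `CN(CC(=O)N1CCc2ccccc2C1)C(=O)c1ccc(S(C)(=O)=O)c([N+](=O)[O-])c1`: > 60000 nM

Both values are limits of the assay and not numbers. Compound 1 gives > 60000 nM in this assay, a limit of the assay and not a number. Compound 2 gives > 60000 nM in this assay, likewise a limit. Compound 1 thus stands nowhere on a scale: it rests at the limit, and every value shown rests there with it (the limit of > 60000 nM in this assay, at which 2 of the 2 values shown sit). Among the measured compounds shown here, no order between compound 1 and compound 2 can be read, and no step between measured compounds is available to calibrate the series.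

The unmeasured compound 3 `CS(=O)(=O)c1ccc(C(=O)NCCCC(=O)N2CCCCC2)cc1[N+](=O)[O-]` differs from compound 1 by ((piperidin-1-yl)carbonyl)methyl in place of diisopropylcarbamoyl on a saturated chain carbon, two bonds along the chain from an amide-type nitrogen. The leaving group and the entering group match in what is counted, and the shared core is kept.

For the measured compounds named here, with no measured step to lean on, the step that the limit leaves unreadable from compound 1 to compound 3 is expected to be none beyond the scatter, in no particular direction. Compound 3 is therefore estimated at 80000 nM in this assay, with a range from 30000 nM to 300000 nM, most likely again reported only as a limit.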

Compound 3, half-maximal inhibitory concentration: > 60000 nM
Compound 3: a limit, no number (the forecaster's own chance of this, stated with the estimate: 85%); the middle value lies beyond the limit too.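

In this assay compound 3 gives > 60000 nM as a limit of the assay and not a number. Among the compounds shown here, no step from compound 1 to compound 3 can be read. The compounds shown leave open any order within the series and whether any change on the shared core gives a number at all: the limit of > 60000 nM in this assay, at which 3 of the 3 values shown sit.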